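From pyridin-4-yl to thiophen-3-yl on a shared core

A few compounds are considered here, and "the series" means these few. Any claim that something is new, unique, unknown or untested is made for them only; others in the source may bear on it.

- Compound 1 `CC(=O)N1N=C(c2ccc3ccccc3c2)OC1c1cccnc1`: 2.86 ug/mL
- Compound 2 `CC(=O)N1N=C(c2ccc3ccccc3c2)OC1c1ccncc1`: 2.17 ug/mL

In a functional assay on HepG2 cells (Homo sapiens) for antiproliferative activity, read by MTT assay, with a stated time of 48 h (on this read-out lower numbers stand for stronger inhibition and higher numbers for weaker inhibition), compound 2 gives 2.17 ug/mL, within the scatter of compound 1. Compound 3 `CC(=O)N1N=C(c2ccc3ccccc3c2)OC1c1ccsc1` carries thiophen-3-yl in place of pyridin-4-yl on a saturated ring carbon. For the measured compounds named here, only one measured step bears on this change, a 1.3-fold lower number from compound 1 to compound 2 (0.12 log units; within the scatter), and it exchanges one pyridinyl group for another. No five-membered aromatic ring has yet been measured, so this evidence is thin. No step beyond the scatter is therefore expected in this assay, and the estimated step is a 1.1-fold higher number from compound 2 to compound 3 (0.03 log units; within the scatter). For compound 3 the expected value is 2.3 ug/mL, with an estimated range of 0.9 ug/mL to 6 ug/mL.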

Compound 3, half-maximal inhibitory concentration: 6.82 ug/mL
For compound 3 the middle estimate is 3.0-fold (0.47 log units) below the measured one; measured number outside the range, above it.
By their numbers in this assay, from the lowest: compounds 2 and 1 (each within the scatter of the next); then compound 3.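

The two pyridinyl groups on this saturated ring carbon had stayed within the scatter of each other, so the position had not yet shown any response to a change of ring. In this assay, thiophen-3-yl moves the number beyond the scatter against both, with a 3.1-fold higher number from compound 2 to compound 3 (0.50 log units; beyond the scatter) and with a 2.4-fold higher number from compound 1 to compound 3 (0.38 log units; beyond the scatter). Both steps point towards weaker inhibition, so exchanging either six-membered pyridinyl ring for this five-membered ring costs activity here.

The compounds shown leave open whether a phenyl or furan-3-yl ring on this carbon would read like thiophen-3-yl or like the pyridinyl groups. Nothing measured here explains the step.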